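Swapping an ester side chain for a free acid

The source may report more compounds than this note shows. Statements on the series, on what has been measured and on what is new or still open speak of the compounds shown alone.

For the measured compounds named here, in a functional assay on Caco-2 cells (Homo sapiens) for antiproliferative activity, read by MTT assay, with a stated time of 48 h (on this read-out lower numbers stand for stronger inhibition and higher numbers for weaker inhibition), compound 3 `CCOC(=O)CN(C)C(=O)c1ccc(C(CC)(CC)c2ccc(OCCC(O)(CC)CC)c(C)c2)n1CC` gives 30300 nM as the only true number so far. Compound 1 `C=CCN(C)C(=O)c1ccc(C(CC)(CC)c2ccc(OCCC(O)(CC)CC)c(C)c2)n1CC` reads > 50000 nM and that is a limit of the assay, not a number. Compound 2 `CCOc1ccc(NC(=O)c2ccc(C(CC)(CC)c3ccc(OCCC(O)(CC)CC)c(C)c3)n2CC)cc1` reads > 50000 nM and that is likewise a limit.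

Compound 4 `CCn1c(C(=O)NC(C)C(=O)O)ccc1C(CC)(CC)c1ccc(OCCC(O)(CC)CC)c(C)c1` has not yet been measured. Its change from compound 3 is (1-carboxyethyl)amino in place of ((ethoxycarbonyl)methyl)(methyl)amino on a carbonyl carbon, counted in full as (1-carboxyethyl)amino in place of ((ethoxycarbonyl)methyl)(methyl)amino on a carbonyl carbon here.

Two measured steps end at compound 3 and bear on this change: an at least 1.6-fold lower number from compound 1 to compound 3 (0.21 log units; that floor lies within the scatter) is one and an at least 1.6-fold lower number from compound 2 to compound 3 (0.21 log units; that floor lies within the scatter) is the other. Also measured is a step that the two limits leave unreadable from compound 1 to compound 2 and it adds no usable size. None of these shows a change beyond the scatter in this assay so no clear gain or loss is expected from this swap, although a slight drift towards weaker inhibition would fit the neighbouring limits. The expected change is a 1.3-fold higher number from compound 3 to compound 4 (0.12 log units; within the scatter) and it remains only an estimate. A reading that is again just a limit is quite possible. The expected value for compound 4 is 40000 nM within an estimated range of 15000 nM to 100000 nM overall.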

Compound 4, half-maximal inhibitory concentration: 46500 nM
Compound 4: the middle estimate sits 1.2-fold (0.07 log units) below what was measured, within the range that was stated.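

In this assay, putting (1-carboxyethyl)amino in place of ((ethoxycarbonyl)methyl)(methyl)amino on the carbonyl carbon gives a 1.5-fold higher number from compound 3 to compound 4 (0.19 log units; within the scatter), so a free carboxylic acid carrying hydrogen-bond donors can replace an ester with none without a change beyond the scatter. The steps from the two compounds that read only as limits are an at least 1.0-fold lower number from compound 2 to compound 4 (0.03 log units; that floor lies within the scatter) and an at least 1.0-fold lower number from compound 1 to compound 4 (0.03 log units; that floor lies within the scatter), and neither separates the new acid from the allyl(methyl)amino or 4-ethoxyphenyl amides. Those two comparisons can therefore give only a floor, not a size: the limit of > 50000 nM in this assay, at which 2 of the 4 values shown sit.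

The swap changes several things at once, since the ester becomes an acid, the methyl on the nitrogen goes and a branched chain enters, so the step cannot say which of these matters, if any does. Still open, on these data alone, is how the same position would read with the ethyl ester of the 1-carboxyethyl group, with an unbranched carboxymethyl group, or with a chain ending in an amine.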